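The compounds below may be only part of what the source reports. "The series", "measured", "known", "first", "only" and "open" are said of these compounds alone.

Compound 1 `COc1ccc(/C=C/c2cc(OC)c(OC)c(OC)c2-c2ccc(F)c(F)c2)cc1`: 6900 nM
Compound 2 `COc1ccc(/C=C/c2cc(OC)c(OC)c(OC)c2-c2ccc(F)c(C)c2)cc1`: 19000 nM

In a functional assay on SK-N-SH cells (Homo sapiens) for cytotoxicity, read by MTT assay, with a stated time of 48 h (a higher number here means a weaker inhibitor, a lower number a stronger inhibitor), compound 1 gives 6900 nM, the lower of the two numbers and so the stronger result. Within the data shown here, its only neighbour, compound 2, gives 19000 nM. The step between them is a 2.8-fold higher number from compound 1 to compound 2 (0.44 log units; beyond the scatter), a modest change beyond the scatter, made by putting methyl in place of fluoro on an aromatic carbon.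

Compound 3 `C=C(c1ccc(OC)cc1)c1cc(OC)c(OC)c(OC)c1-c1ccc(F)c(F)c1` has not yet been measured. It holds the same atoms as compound 1, joined differently: 1-(4-methoxyphenyl)ethenyl in place of 2-(4-methoxyphenyl)ethenyl on an aromatic carbon. In words, 1-(4-methoxyphenyl)ethenyl stands in place of 2-(4-methoxyphenyl)ethenyl, so the shared core now carries the ethenyl group through a different carbon.

Among the measured compounds shown here, the one measured step, a 2.8-fold higher number from compound 1 to compound 2 (0.44 log units; beyond the scatter), involves a different group, so it offers only a rough sense of scale. For the measured compounds named here, no measured compound shows what this rearrangement does, and the data give no direction for it. The expected step is therefore small but quite uncertain: a 1.2-fold lower number from compound 1 to compound 3 (0.06 log units; within the scatter), as an estimate. For compound 3 the estimated value is 6000 nM, with an expected range of 1200 nM to 30000 nM.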

Compound 3, half-maximal inhibitory concentration: 7500 nM
For compound 3 the middle estimate is 1.3-fold (0.10 log units) below the measured one; the range from low to high includes it.
By their numbers in this assay, from the lowest: compounds 1 and 3 (each within the scatter of the next); then compound 2.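

In this assay, shifting the attachment so that 1-(4-methoxyphenyl)ethenyl stands in place of 2-(4-methoxyphenyl)ethenyl, on the aromatic carbon ortho to a 3,4-difluorophenyl group, gives a 1.1-fold higher number from compound 1 to compound 3 (0.04 log units; within the scatter) and so leaves compound 1 and compound 3 indistinguishable in this read-out. Among these compounds, the earlier compounds showed only what swapping fluoro for methyl does, whereas this result is the first reading at this position: here the same atoms can be joined through a different ethenyl carbon, and the number stays within the scatter of the one for compound 1. Nothing available here explains why these two arrangements read alike.

The compounds shown leave open whether the same rearrangement would also read alike with the methyl-bearing group of compound 2 in place of the 3,4-difluorophenyl group. They also do not show how this position responds to a truly different group, such as an amine, a carboxylic acid or a longer chain in place of the ethenyl link.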